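Swapping the Thiophene for Fluorophenyl on an Unacylated Amine

The compounds below may be only part of what the source reports. "The series", "measured", "known", "first", "only" and "open" are said of these compounds alone.

Compound 1 `Nc1cccc(-c2cn3nc(-c4cccs4)sc3n2)c1` carries a hydrogen on a nitrogen on an aromatic ring. In a functional assay on HeLa cells (Homo sapiens) for inhibition, read by cell counting, with a stated time of 4 days (a lower number here means a stronger inhibitor, a higher number a weaker inhibitor), compound 1 gives only a limit, > 250000 nM, and so stands at the limit of > 250000 nM in this assay, at which 1 of the 2 values shown sits, rather than at a number. Compound 2 `C=C(Br)C(=O)Nc1cccc(-c2cn3nc(-c4cccs4)sc3n2)c1` carries a (1-bromoethenyl)carbonyl on that nitrogen, and in this assay compound 2 gives 670 nM. For the measured compounds named here, the single measured step, an at least 370-fold lower number from compound 1 to compound 2 (2.57 log units; beyond the scatter), concerns that carbonyl group alone and leaves the rest of the shared core untouched. Compound 3 `Nc1cccc(-c2cn3nc(-c4ccc(F)cc4)sc3n2)c1` keeps the hydrogen on the nitrogen of compound 1 and differs from it elsewhere: 4-fluorophenyl in place of thiophen-2-yl on an aromatic carbon. No measured step touches the aromatic group at that carbon, so nothing shown speaks for a change beyond the scatter, and compound 3 is expected to stay at the limit, a number no higher from compound 1 to compound 3 (the limit leaves the size open). The estimate for compound 3 is 250000 nM, with a range from 50000 nM to 1000000 nM.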

Compound 3, half-maximal inhibitory concentration: >= 250000 nM
Compound 3 gave a limit, no number; the forecaster's own chance of this, stated with the estimate: 85%; the middle value sits exactly at the limit.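

Compound 1 and compound 3 each give only a limit in this assay, and the step between them cannot be read. The compounds shown leave open whether 4-fluorophenyl in place of thiophen-2-yl matters at all once a (1-bromoethenyl)carbonyl sits on that nitrogen.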